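Series notes: propoxy to ethoxy step in cytotoxicity

The source may hold more compounds than are shown below. What is called first, only, known or untested is meant among the compounds shown, and "the series" means these compounds.

Measured in an ADME assay on BEAS-2B cells (Homo sapiens) for cytotoxicity, read by MTT assay, with a stated time of 72 h; on this read-out higher numbers stand for weaker inhibition of growth and lower numbers for stronger inhibition of growth:
compound 1 `CC(C)COC(=O)Nc1ccc([Se][Se]c2ccc(NC(=O)OCC(C)C)cc2)cc1` gives 42700 nM
compound 2 `N#C[Se]c1ccc(NC(=O)Oc2ccc(F)cc2)cc1` gives 45600 nM
compound 3 `CCCOC(=O)Nc1ccc([Se]C#N)cc1` gives 46300 nM

Compound 3 holds the highest of the three numbers, but its gap to compound 2 and its gap to compound 1 both lie within the scatter, so the three measured compounds read alike on this read-out and no order among them can be drawn. Compound 1 carries a diselenide linkage, compound 2 an aryl ester, compound 3 a propyl ester; none of these variations moves the number beyond the scatter.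

Compound 4 `CCOC(=O)Nc1ccc([Se]C#N)cc1` differs from compound 3 by hydrogen in place of methyl on a saturated chain carbon, two bonds along the chain from an oxygen next to a carbonyl group. Among the compounds with values here, no step between measured compounds is recorded for a change of this kind. Given that wider variation across compounds 1, 2 and 3 stays within the scatter, the expectation for the step of a 1.0-fold lower number from compound 3 to compound 4 (0.01 log units; within the scatter) is no change beyond the scatter, in either direction. Compound 4 is therefore expected to give about 45000 nM in this assay, with a range from 25000 nM to 80000 nM.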

Compound 4, concentration for total growth inhibition: 46900 nM
Beside the measured number, compound 4's estimate is 1.0-fold (0.02 log units) below it; low and high end bracket the measured number.
By their numbers in this assay, from the lowest: compounds 1, 2, 3 and 4 (each within the scatter of the next).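

In this assay the propoxy to ethoxy change gives a 1.0-fold higher number from compound 3 to compound 4 (0.01 log units; within the scatter) and is the only step shown that isolates a single place. Within the data shown here, removing this methyl, on a saturated chain carbon two bonds along the chain from an oxygen next to a carbonyl group, therefore leaves the number unmoved beyond the scatter, a direct reading that the earlier compounds, with no pair differing in one place, could not give. Nothing available explains this flat step.

From the compounds shown here alone, whether the number also holds with a longer chain such as hexyl, or with an amine or a carboxylic acid in place of the ethyl group, remains open. This single step also leaves open whether the same change would read alike on the diselenide form seen in compound 1.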